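The compounds below may be only part of what the source reports. "The series", "measured", "known", "first", "only" and "open" are said of these compounds alone.

Measured compounds in a functional assay on PC-3 cells (Homo sapiens) for inhibition; on this read-out lower numbers stand for stronger inhibition of growth and higher numbers for weaker inhibition of growth:
compound 1, `O=C(COc1ccc(/C=C2\SC(=O)NC2=O)cc1)Nc1ccc([N+](=O)[O-])cc1`, > 100000 nM
compound 2, `O=C(COc1ccc(/C=C2\SC(=O)NC2=O)cc1)Nc1ccc(F)cc1`, > 100000 nM

Compound 1 does not stand at a number in this assay at all; its result is only a limit of the assay, > 100000 nM. Compound 2 likewise gives only a limit, > 100000 nM. Going by the values given here, the one measured step, a step that the two limits leave unreadable from compound 1 to compound 2, is therefore of a size that cannot be read, and the two results say no more than that both compounds sit at the same point, (the limit of > 100000 nM in this assay, at which 2 of the 2 values shown sit).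

The unmeasured compound 3, `O=C(COc1ccc(/C=C2\SC(=O)NC2=O)cc1)Nc1ccc(Cl)cc1`, differs from compound 1 by chloro in place of nitro on an aromatic carbon. The step that bears on it is the fluoro-for-nitro exchange, whose size is hidden by the two limits, so no readable step in this assay can be expected from it either. Compound 3 is estimated at 150000 nM, within 50000 nM to 500000 nM, meaning an expected step that the limit leaves unreadable from compound 1 to compound 3, most likely reported again as a limit.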

Compound 3, concentration for 50% growth inhibition: 83400 nM
The estimate for compound 3 lay 1.8-fold (0.25 log units) above the measured number; low and high end bracket the measured number.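

In this assay, going by these compounds alone, chloro at this place, para to a large group, gives the only number rather than a limit, so growth inhibition on the shared core can now be read. As far as these compounds go, the exchange of nitro for chloro (an at least 1.1-fold lower number from compound 1 to compound 3 (0.07 log units; that floor lies within the scatter)) and of fluoro for chloro (an at least 1.1-fold lower number from compound 2 to compound 3 (0.07 log units; that floor lies within the scatter)) gives only floors, and the true size of either step stays unknown, as does the size of the step between the two limits, which cannot be read. The other two results remain limits of the assay: the limit of > 100000 nM in this assay, at which 2 of the 3 values shown sit.

The compounds shown leave open whether bromo, methoxy or an amine at this place would give a readable number. They also leave open whether any such number would lie clearly beyond that of compound 3.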